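Swapping a Ring-Bearing Group for a Ring-Free One

The source may report more compounds than this note shows. Statements on the series, on what has been measured and on what is new or still open speak of the compounds shown alone.

Compound 1 `O=c1ccc(-c2ccccc2)nn1CCCCNC(=S)Nc1ccc(Cl)cc1` gives 43.2% in a functional assay on the whole organism with Rattus norvegicus as the target, at a dose of 100 mg/kg; a lower number here means less inhibition, a higher number more inhibition at the dose given (going by the name of the read-out).
Compound 2 `O=c1ccc(-c2ccccc2)nn1CCCCNC(=S)NC1CCCCC1` gives 18.1% in this assay.
Compound 3 `O=c1ccc(-c2ccccc2)nn1CCCCNC(=S)Nc1cccc2ccccc12` gives 42.3% in this assay.

Compound 2 stands lowest of the three numbers: the change from 4-chlorophenyl to cyclohexyl gave a number 25.1 percentage points lower from compound 1 to compound 2 (beyond the scatter), and going on to naphthalen-1-yl gave a number 24.2 percentage points higher from compound 2 to compound 3 (beyond the scatter). Compound 1 and compound 3 sit close together, their step of a number 0.9 percentage points lower from compound 1 to compound 3 (within the scatter) staying within the scatter.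

Compound 4 `C/N=C(\NC#N)NCCCCn1nc(-c2ccccc2)ccc1=O` differs from compound 2 by a group of 6 heavy atoms (3 carbon, 3 nitrogen; no ring) in place of a group of 9 heavy atoms (7 carbon, 1 nitrogen, 1 sulfur; one six-membered non-aromatic ring of carbon only), on an amine nitrogen. Within the data shown here, the two steps that bear on this are the cyclohexyl swaps just named, both modest and both at the same position, yet neither removes the ring-bearing group entirely or brings in a triple bond, so no measured step matches this change. With compound 2 already the lowest and compound 4 also lacking any ring on this nitrogen, the expectation is a step within the scatter, a number 1.9 percentage points higher from compound 2 to compound 4 (within the scatter), though with wide uncertainty. Compound 4 is therefore estimated at 20% in this assay, in the range 5% to 40%.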

Compound 4, a percentage reported as inhibition, in the whole organism at one dose (the size of the read-out at that dose, not a potency): 79%
Estimate against measurement, compound 4: 59 percentage points below, outside the stated range (above it).
By their numbers in this assay, from the lowest: compound 2; then compounds 3 and 1 (each within the scatter of the next); then compound 4.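

In this assay, a group with no ring on this amine nitrogen gives a number 60.9 percentage points higher from compound 2 to compound 4 (beyond the scatter) and so shows that a ring at this position is not needed for a high number. The earlier compounds shown here all kept the sulfur-bearing group and changed only the ring, with compound 1 at 43.2% and compound 3 at 42.3% as their highest numbers, while compound 4 at 79% shows that replacing the whole group can go well beyond them. No measurement shown here gives an explanation for the size of this step.

On these data alone, compound 4 loses the sulfur and the cyclohexyl ring and gains the nitrile all in one change, so it remains open which of these parts matters. A cyclohexyl on the nitrile-bearing group, or a methyl on the sulfur-bearing group, would separate them.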